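A few compounds are considered here, and "the series" means these few. Any claim that something is new, unique, unknown or untested is made for them only; others in the source may bear on it.

Measured compounds:
- compound 1, `Cc1c(C)c2c(c(C)c1O)CC[C@@](C)(CC[N+](C)(C)C)O2`: 2300 nM
- compound 2, `Cc1c(C)c2c(c(C)c1O)CCC(C)(C(=O)[N-][N+](C)(C)C)O2`: 14000 nM
- compound 3, `Cc1c(C)c2c(c(C)c1O)CC[C@@](C)(CC(=O)O)O2`: 17000 nM

In a functional assay (brain) for inhibition, with Rattus norvegicus as the target (on this read-out higher numbers stand for weaker inhibition and lower numbers for stronger inhibition), compound 3 gives 17000 nM, the highest of the three numbers. The gap to compound 2 is within the scatter, so the two cannot be ordered; the gap to compound 1 is beyond it, a 7.4-fold higher number from compound 1 to compound 3 (0.87 log units; beyond the scatter).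

Compound 4, `Cc1c(C)c2c(c(C)c1O)CC[C@@](C)(CC(=O)[N-][N+](C)(C)C)O2`, differs from compound 3 on a carbonyl carbon: a group of 5 heavy atoms (3 carbon, 2 nitrogen; no ring) in place of one oxygen atom, on a carbonyl carbon

For the measured compounds named here, no measured step covers this exact change. Going by the values given here, the only step, from compound 1 to compound 3, swaps a chain bearing a quaternary nitrogen for a carboxylic acid and is modest. Compound 2 carries the same entering group on a carbonyl directly attached to the core and gives 14000 nM, a number that sits within the scatter of compound 3. On that basis compound 4 is expected to stay close to compound 3, with a step of a 1.5-fold lower number from compound 3 to compound 4 (0.19 log units; within the scatter) in this assay at most, not clearly beyond the scatter.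

Estimate for compound 4 in this assay: 11000 nM, range 3500 nM to 35000 nM.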

Compound 4, half-maximal inhibitory concentration: 9000 nM
Estimate against measurement, compound 4: 1.2-fold (0.09 log units) above; the range from low to high includes it.
By their numbers in this assay, from the lowest: compound 1; then compounds 4, 2 and 3 (each within the scatter of the next).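

On a carbonyl carbon whose other neighbour is a saturated chain carbon, the 5-heavy-atom group entering in place of hydroxy gives a 1.9-fold lower number from compound 3 to compound 4 (0.28 log units; within the scatter) in this assay and so does not separate compound 4 from the carboxylic acid. The chain of compound 1 still stands apart from the new group, with a 3.9-fold higher number from compound 1 to compound 4 (0.59 log units; beyond the scatter) in this assay and thus beyond the scatter, as it does from the carboxylic acid, with a 7.4-fold higher number from compound 1 to compound 3 (0.87 log units; beyond the scatter) in the same read-out. Placing the new group on this carbonyl carbon therefore does not bring the series level with compound 1. No measurement at hand accounts for this result.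

A simple amide or a methyl ester on the same carbonyl carbon remains open, since neither group appears among these compounds. As far as these compounds go, a longer chain carrying the carboxylic acid also remains open.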